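Replacing cyano with benzoyl in compound 3

The source may hold more compounds than are shown below. What is called first, only, known or untested is meant among the compounds shown, and "the series" means these compounds.

In a functional assay (blood) for inhibition, with Homo sapiens as the target (on this read-out lower numbers stand for stronger inhibition and higher numbers for weaker inhibition), compound 1 `N#Cc1cc(-c2ccccc2)c2ccc(OCc3cccc(C4(O)CCOCC4)c3)cc2c1` gives 100 nM as its value. For compound 2 `OC1(c2cccc(COc3ccc4c(-c5ccccc5)cc(-c5nn[nH]n5)cc4c3)c2)CCOCC1` the assay reports only a limit (> 3000 nM). Compound 3 `N#Cc1cc(-c2ccoc2)c2ccc(OCc3cccc(C4(O)CCOCC4)c3)cc2c1` gives 10 nM and so holds the lower of the two actual numbers. That advantage came with furan-3-yl in place of phenyl on an aromatic carbon, a modest step (a 10-fold lower number from compound 1 to compound 3 (1.00 log units; beyond the scatter)). Compound 4 `O=C(c1ccccc1)c1cc(-c2ccoc2)c2ccc(OCc3cccc(C4(O)CCOCC4)c3)cc2c1` keeps the furan-3-yl group and differs from compound 3 by benzoyl in place of cyano on an aromatic carbon. The only measured replacement of cyano, by 2H-tetrazol-5-yl, was a large step (an at least 30-fold higher number from compound 1 to compound 2 (1.47 log units; beyond the scatter)). It involved a different group on the phenyl series, so it warns of a loss without fixing its size. A modest rise is therefore expected in this assay (a 3.0-fold higher number from compound 3 to compound 4 (0.48 log units; beyond the scatter)). For compound 4 the estimated value is 30 nM within an expected range of 7 nM to 150 nM in this read-out.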

Compound 4, half-maximal inhibitory concentration: 200 nM
Estimate against measurement, compound 4: 6.7-fold (0.82 log units) below; the whole stated range lies below it.
By their numbers in this assay, from the lowest: compound 3; then compounds 1 and 4 (each within the scatter of the next). At a limit, above all of these: compound 2.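

In this assay, benzoyl in place of cyano on an aromatic carbon gives a 20-fold higher number from compound 3 to compound 4 (1.30 log units; beyond the scatter), so the position does not tolerate this change even though the entering group, like cyano, carries no net charge and has no hydrogen-bond donor. Until now, the only replacement of cyano shown was 2H-tetrazol-5-yl alongside a phenyl group, read only against a limit; compound 4 now gives an actual number for such a loss with the furan-3-yl group in place, and both replacements shown raise the number. No measurement shown here bears on the reason for this rise.

The compounds shown leave open whether an acetyl or a carboxamide on this carbon would hold the value of compound 3. They also leave open how benzoyl would act alongside the phenyl group of compound 1.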